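The source may report more compounds than this note shows. Statements on the series, on what has been measured and on what is new or still open speak of the compounds shown alone.

Three measured compounds share one core and differ only in the group on the aromatic nitrogen. Compound 1 `CC1(C)OCC(Cn2cc(Cn3c4c(c5ccccc53)C(=O)c3c[n+]([O-])c5ccccc5c3C4=O)nn2)O1` gives 5510 nM in a toxicity assay on HEK-293T cells (Homo sapiens) for cytotoxicity, read by MTT assay, with a stated time of 72 h; a lower number here means a stronger inhibitor, a higher number a weaker inhibitor. Compound 2 `O=C1c2c[n+]([O-])c3ccccc3c2C(=O)c2c1c1ccccc1n2Cc1cn(CC(O)CO)nn1` gives 760 nM in this assay. Compound 3 `O=C1c2c[n+]([O-])c3ccccc3c2C(=O)c2c1c1ccccc1n2Cc1cn([C@@H]2O[C@H](CO)[C@@H](O)[C@H](O)[C@H]2O)nn1` gives 940 nM in this assay, which places it second highest of the three numbers; its nearest neighbour is compound 2 and its furthest is compound 1. The steps to it read a 5.9-fold lower number from compound 1 to compound 3 (0.77 log units; beyond the scatter) and a 1.2-fold higher number from compound 2 to compound 3 (0.09 log units; within the scatter). Compound 4 `O=C1c2c[n+]([O-])c3ccccc3c2C(=O)c2c1c1ccccc1n2Cc1cn(C[C@H](O)CO)nn1` is the next entry: 2,3-dihydroxypropyl in place of 3,4,5-trihydroxy-6-(hydroxymethyl)oxan-2-yl on an aromatic nitrogen. The change runs the measured step from compound 2 to compound 3 in reverse, since compound 4 bears the 2,3-dihydroxypropyl group of compound 2 with one defined stereocentre, and that step lay within the scatter. The step of a 7.3-fold lower number from compound 1 to compound 2 (0.86 log units; beyond the scatter) bears on it only in that the open-chain diol already sits at the lower end of the set. The step in this assay is therefore expected to be a 1.2-fold lower number from compound 3 to compound 4 (0.07 log units; within the scatter), a change not beyond the scatter. For compound 4 the expected value is 800 nM, with a range from 400 nM to 1600 nM.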

Compound 4, half-maximal inhibitory concentration: 8880 nM
The estimate for compound 4 lay 11-fold (1.05 log units) below the measured number, outside the stated range (above it).
By their numbers in this assay, from the lowest: compounds 2 and 3 (each within the scatter of the next); then compounds 1 and 4 (each within the scatter of the next).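

Drawn with a defined S configuration, the 2,3-dihydroxypropyl group on the aromatic nitrogen no longer matches the 3,4,5-trihydroxy-6-(hydroxymethyl)oxan-2-yl group in this assay, with a 9.4-fold higher number from compound 3 to compound 4 (0.98 log units; beyond the scatter). An open-chain diol therefore does not by itself secure the lower numbers, as a 1.6-fold higher number from compound 1 to compound 4 (0.21 log units; within the scatter) leaves this diol within the scatter of the 2,2-dimethyl-1,3-dioxolan-4-yl compound. With the same atoms and bonds on both sides, a 12-fold higher number from compound 2 to compound 4 (1.07 log units; beyond the scatter) has one recorded difference to point to: the fact that one of compounds 2 and 4 is drawn with a defined configuration and the other without, at the place where they differ.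

As far as these compounds go, what compound 2 holds at the undefined stereocentre stays open, and so does how the opposite configuration, drawn as a single form, would read. Also open, from the compounds shown here alone, is how an amine or a carboxylic acid in place of the diol would read on this aromatic nitrogen.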